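Replacing methylsulfanyl with methyl in compound 4

A few compounds are considered here, and "the series" means these few. Any claim that something is new, unique, unknown or untested is made for them only; others in the source may bear on it.

- compound 1 `CSc1cc(C)nc(Cl)c1NC(=O)N(Cc1ccc(Oc2ccc(F)cc2)cc1)C1CCCCCC1`: 0.17 mg/kg
- compound 2 `Cc1cc(S(C)(=O)=O)c(NC(=O)N(Cc2ccc(Oc3ccc(F)cc3)cc2)C2CCCCCC2)c(Cl)n1`: > 1 mg/kg, a limit
- compound 3 `CSc1cc(C)nc(C)c1NC(=O)N(Cc1ccc(Oc2ccc(F)cc2)cc1)C1CCCCCC1`: < 1 mg/kg, a limit

In a functional assay on the whole organism with Rattus norvegicus as the target (on this read-out higher numbers stand for an effect only at larger amounts of compound and lower numbers for an effect already at smaller amounts), compound 3 stands at < 1 mg/kg, which is a limit and not a number. Compound 4 `Cc1cc(C)c(NC(=O)N(Cc2ccc(Oc3ccc(F)cc3)cc2)C2CCCCCC2)c(C)n1` differs from compound 3 in one place: methyl in place of methylsulfanyl on an aromatic carbon. For the measured compounds named here, the one readable step that alters this methylsulfanyl group is an at least 5.8-fold higher number from compound 1 to compound 2 (0.76 log units; beyond the scatter), which is beyond the scatter. Going by the values given here, the only methyl swap gives a step that the limit leaves unreadable from compound 1 to compound 3, so it offers no size. Losing the methylsulfanyl group in compound 4 is therefore expected to matter modestly, towards a higher number, with the direction uncertain. The expected change is a step that the limit leaves unreadable from compound 3 to compound 4. For compound 4 the estimate is 0.6 mg/kg, with an expected range from 0.15 mg/kg to 2.5 mg/kg.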

Compound 4, dose for half-maximal effect: 0.77 mg/kg
Estimate against measurement, compound 4: 1.3-fold (0.11 log units) below, within the range that was stated.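

The first firm size for losing the methylsulfanyl group comes with a second swap, chloro to methyl: this assay shows a 4.5-fold higher number from compound 1 to compound 4 (0.66 log units; beyond the scatter). The other readable step is an at least 1.2-fold lower number from compound 2 to compound 4 (0.11 log units; that floor lies within the scatter), so it sets no clear gap. Compound 3 carries only a limit, and the steps that depend on it cannot be read: the limit of < 1 mg/kg in this assay, at which 1 of the 4 values shown sits.

Going by these compounds, how much of the rise belongs to methyl in place of methylsulfanyl, and how much to methyl in place of chloro, stays open. So does the effect of an amine or a methoxy group in this place.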